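The source may report more compounds than this note shows. Statements on the series, on what has been measured and on what is new or still open speak of the compounds shown alone.

Compound 1, `NC(=S)N1CCc2c(OCCCCCOc3ccc(Cl)cc3)cccc21`, gives a limit of > 50000 nM in an ADME assay on Huh-7 cells (Homo sapiens) for cytotoxicity; a lower number here means that less compound is tolerated, a higher number that more compound is tolerated.
Compound 2, `O=C(NC(=S)N1CCc2c(OCCCCCOc3ccc(Cl)cc3)cccc21)c1cccc([N+](=O)[O-])c1`, gives 12100 nM in this assay.
Compound 3, `O=C(NC(=S)N1CCc2c(OCCCCCOc3ccc(Cl)cc3)cccc21)c1ccc(F)cc1`, gives 31100 nM in this assay.

Among the two plain numbers, compound 2 has the lowest; the nearest is compound 3, with a 2.6-fold higher number from compound 2 to compound 3 (0.41 log units; beyond the scatter). Compound 4, `O=C(NC(=S)N1CCc2c(OCCCCCOc3ccc(Cl)cc3)cccc21)C1CCCC1`, differs from compound 2 in one place: cyclopentyl in place of 3-nitrophenyl on a carbonyl carbon. Going by the values given here, two measured steps bear on this. The step of a 2.6-fold higher number from compound 2 to compound 3 (0.41 log units; beyond the scatter) shows that exchanging the 3-nitrophenyl on the carbonyl carbon for another group raised the number, and an at least 4.1-fold lower number from compound 1 to compound 2 (0.61 log units; beyond the scatter) shows that adding the (3-nitrophenyl)carbonyl lowered it from the limit. A modest rise is therefore expected, a 2.1-fold higher number from compound 2 to compound 4 (0.32 log units; beyond the scatter). Compound 4 is estimated at 25000 nM, expected between 10000 nM and 60000 nM.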

Compound 4, half-maximal cytotoxic concentration: > 50000 nM
Compound 4: only a limit was reported (the forecaster's own chance of this, stated with the estimate: 25%); middle value at least 2.0-fold (0.30 log units) from the limit.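

Putting cyclopentyl in place of 3-nitrophenyl on the carbonyl carbon gives an at least 4.1-fold higher number from compound 2 to compound 4 (0.61 log units; beyond the scatter), so in this assay this position can carry a non-aromatic ring, and compound 2 is clearly less tolerated. Against the 4-fluorophenyl of compound 3, the change gives an at least 1.6-fold higher number from compound 3 to compound 4 (0.20 log units; that floor lies within the scatter), so this comparison shows no firm difference. The step between compound 1 and compound 4 cannot be read, because both values are limits: the limit of > 50000 nM in this assay, at which 2 of the 4 values shown sit.

Going by these compounds, it remains open whether an unsubstituted phenyl, a small acetyl group or a cyclopentyl ring bearing an amine would behave like cyclopentyl at this position.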